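The source may report more compounds than this note shows. Statements on the series, on what has been measured and on what is new or still open speak of the compounds shown alone.

Compound 1, `NC(=O)c1c[nH]c([C@@H](O)c2ccccc2)cc1=O`, carries a carbamoyl group on its core. In a functional assay on HeLa cells (Homo sapiens) for inhibition, read by sulforhodamine B assay, with a stated time of 48 h (on this read-out higher numbers stand for weaker inhibition and lower numbers for stronger inhibition), compound 1 gives > 50000 nM, which is a limit of the assay rather than a measured number. For the measured compounds named here, compound 2, `COC(=O)c1c[nH]c([C@@H](O)c2ccccc2)cc1=O`, is the one measured neighbour of compound 1, differing by methoxy in place of amino on a carbonyl carbon. In this assay compound 2 gives > 50000 nM, again a limit and not a number. The step that the two limits leave unreadable from compound 1 to compound 2 therefore has no readable size, because of the limit of > 50000 nM in this assay, at which 2 of the 2 values shown sit. Compound 3, `NC(=O)c1cn(CCO)c([C@@H](O)c2ccccc2)cc1=O`, is not yet measured. It differs from compound 1 by 2-hydroxyethyl in place of hydrogen on an aromatic nitrogen. Going by the values given here, no measured step touches this aromatic nitrogen, so nothing in the data speaks directly to the change, and the only step available gave no readable size at all. Since both measured compounds sit at the limit, the expectation for compound 3 rests on that alone. Compound 3 is expected to give 50000 nM, between 15000 nM and 200000 nM, most likely reported as a limit once more. The step of a number no higher from compound 1 to compound 3 (the limit leaves the size open) is expected to be no change beyond the scatter.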

Compound 3, half-maximal inhibitory concentration: > 50000 nM
Compound 3: only a limit was reported (the forecaster's own chance of this, stated with the estimate: 75%); the middle value lies on the limit itself.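

In this assay compound 3, like compound 1, is reported only as a limit and not as a number, so no size can be read for the step between them: the limit of > 50000 nM in this assay, at which 3 of the 3 values shown sit. The compounds shown leave open whether 2-hydroxyethyl in place of hydrogen on the aromatic nitrogen changes inhibition at all, and how strongly any of the three compounds inhibits.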